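Ethynyl in place of (methylsulfonyl)oxy on the pyridine

The source may report more compounds than this note shows. Statements on the series, on what has been measured and on what is new or still open speak of the compounds shown alone.

Measured so far, in a functional assay on CHO cells for agonist activity at metabotropic glutamate receptor 5 (Homo sapiens), read by inositol phosphate accumulation; a lower number here means a stronger inhibitor, a higher number a weaker inhibitor:
Compound 1 `Cc1nc(C#Cc2cccc(O)c2)cs1` gives 654 nM.
Compound 3 `Cc1nc(C#Cc2ccc(OS(C)(=O)=O)nc2)cs1` gives 2340 nM.
Compound 2 `O=C(Nc1nc(C#Cc2cccnc2)cs1)Nc1ccc(F)cc1F` reaches only a limit, > 10000 nM.

Compound 3 stands at the highest of the two numbers; compound 1 sits lower by a gap beyond the scatter. Compound 2 sits at the limit (the limit of > 10000 nM in this assay, at which 1 of the 3 values shown sits).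

Compound 4 `C#Cc1ccc(C#Cc2csc(C)n2)cn1` differs from compound 3 in one place: ethynyl in place of (methylsulfonyl)oxy on an aromatic carbon. For the measured compounds named here, no measured pair shows this change, so the size of the step is uncertain; the expectation is a move toward a lower number in this assay, beyond the scatter. Compound 4 is estimated at 800 nM, with a range from 200 nM to 4000 nM. This estimate means a step of a 2.9-fold lower number from compound 3 to compound 4 (0.47 log units; beyond the scatter).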

Compound 4, half-maximal inhibitory concentration: 2950 nM
Beside the measured number, compound 4's estimate is 3.7-fold (0.57 log units) below it, and the stated range covers the measured number.
By their numbers in this assay, from the lowest: compound 1; then compounds 3 and 4 (each within the scatter of the next). At a limit, above all of these: compound 2.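

On the aromatic carbon next to the ring nitrogen, ethynyl in place of (methylsulfonyl)oxy gives a 1.3-fold higher number from compound 3 to compound 4 (0.10 log units; within the scatter) in this assay. The leaving group has 5 heavy atoms and 3 hydrogen-bond acceptors and the entering group has 2 heavy atoms and 0 acceptors, yet this assay does not separate them. No measurement at hand bears on why these two groups give values within the scatter.

From the compounds shown here alone, whether an amine, a carboxylic acid or a longer chain on this carbon would separate from these two groups stays open.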